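Swapping the amide aryl group on a shared flavonol core

This account rests on a few compounds, and the source may have more. Where it says the series, first, only, none or still open, it means among the compounds named here.

Of the compounds shown here, two sharing one core have been measured in a functional assay on GTL 16 cells for antiproliferative activity against GTL 16 cell line (Homo sapiens), read by CCK-8 assay, with a stated time of 72 h; a higher number here means a weaker inhibitor, a lower number a stronger inhibitor. Compound 1 `O=C(Nc1cccc(-c2oc3cc(-c4ccc(F)cc4)ccc3c(=O)c2O)c1)c1ccc(F)cc1F` gives 9640 nM, and compound 2 `Cc1cccc(C(=O)Nc2cccc(-c3oc4cc(-c5ccc(F)cc5)ccc4c(=O)c3O)c2)c1` gives 10900 nM. The only measured step between them, a 1.1-fold higher number from compound 1 to compound 2 (0.05 log units; within the scatter), lies within the scatter, so on the numbers shown compound 1 and compound 2 cannot be told apart.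

Compound 3 `CCc1ccc(C(=O)Nc2cccc(-c3oc4cc(-c5ccc(F)cc5)ccc4c(=O)c3O)c2)cc1` is not yet measured. It differs from compound 1 in one place: 4-ethylphenyl in place of 2,4-difluorophenyl on a carbonyl carbon. For the measured compounds named here, the one measured step that bears on this change is a 1.1-fold higher number from compound 1 to compound 2 (0.05 log units; within the scatter), which also exchanged the 2,4-difluorophenyl on the carbonyl carbon for a plain carbon-only aromatic ring and produced no movement beyond the scatter. Nothing in the data separates a 3-methylphenyl from a 4-ethylphenyl at that place, so no step beyond the scatter is expected from compound 1 to compound 3, in either direction.

Compound 3 is therefore expected to give about 10000 nM in this assay, within a range from 4500 nM to 22000 nM. The expected step is a 1.0-fold higher number from compound 1 to compound 3 (0.02 log units; within the scatter).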

Compound 3, half-maximal inhibitory concentration: 24600 nM
The estimate for compound 3 lay 2.5-fold (0.39 log units) below the measured number, outside the stated range (above it).
By their numbers in this assay, from the lowest: compounds 1 and 2 (each within the scatter of the next); then compound 3.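

At the aryl group on the amide carbonyl, the identity of the carbon-only aromatic ring now makes a measurable difference in this assay: the exchange gives a 2.6-fold higher number from compound 1 to compound 3 (0.41 log units; beyond the scatter) and, against the other measured ring, a 2.3-fold higher number from compound 2 to compound 3 (0.35 log units; beyond the scatter). Both steps are modest but beyond the scatter, so this place is not indifferent to every such swap, as the first pair alone might have suggested, and compound 3 is the weakest inhibitor of the three while compound 1 and compound 2 remain indistinguishable. The data shown offer no evidence on the reason for this difference.

The compounds shown leave open whether the ethyl group itself or its place on the ring sets compound 3 apart, a question that 4-methylphenyl and 3-ethylphenyl at the same carbonyl carbon would address. They also leave open whether a longer chain such as 4-butylphenyl would raise the number further, and how a ring carrying an amine or a carboxylic acid would behave at this place.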